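Chloro for methoxy: working notes on compound 2 and compound 3

A few compounds are considered here, and "the series" means these few. Any claim that something is new, unique, unknown or untested is made for them only; others in the source may bear on it.

The pair is read in a functional assay on MDA-MB-231 cells (Homo sapiens) for cytotoxicity, read by MTT assay, with a stated time of 48 h; on this read-out higher numbers stand for weaker inhibition and lower numbers for stronger inhibition. Compound 1 `COc1ccc(CNc2ccnc(N3CCN(C)CC3)n2)cc1` opens the set; in this assay compound 1 gives no number but only a limit of the assay, > 200000 nM. Compound 2 `COc1ccc(Nc2nccc(N3CCN(C)CC3)n2)cc1` follows; in this assay compound 2 likewise returns only a limit, > 200000 nM. For the measured compounds named here, compound 2 therefore sits at the ceiling of the values shown, and the one other value sits there too: the limit of > 200000 nM in this assay, at which 2 of the 2 values shown sit. Going by the values given here, no step between measured compounds is available, so no measured change in this assay guides the next move. Compound 3 `CN1CCN(c2ccnc(Nc3ccc(Cl)cc3)n2)CC1` differs from compound 2 by chloro in place of methoxy on an aromatic carbon. Because the limit of > 200000 nM in this assay, at which 2 of the 2 values shown sit, places both shown values at the limit, the expected step is a number no higher from compound 2 to compound 3 (the limit leaves the size open), none beyond the scatter. Compound 3 is estimated at 200000 nM, within 60000 nM to 400000 nM, and is expected most likely to return a limit rather than a number.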

Compound 3, half-maximal inhibitory concentration: > 200000 nM
Compound 3 was reported as a limit; the forecaster's own chance of this, stated with the estimate: 70%; the middle value sits exactly at the limit.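

Compound 2 and compound 3 both stand as limits in this assay, so no step can be read between them: the limit of > 200000 nM in this assay, at which 3 of the 3 values shown sit. The compounds shown leave open whether chloro in place of methoxy changes the read-out in this assay, and what number any of them would give.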